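Aryl hydrazone series: estimating compound 4

A few compounds are considered here, and "the series" means these few. Any claim that something is new, unique, unknown or untested is made for them only; others in the source may bear on it.

Measured so far in a functional assay on ECa-109 cells for antiproliferative activity against ECa-109 cell line (Homo sapiens), read by MTT assay, with a stated time of 72 h; on this read-out higher numbers stand for weaker inhibition and lower numbers for stronger inhibition:
compound 1 `C/C(=N\NC(=O)c1cccc(S(=O)(=O)N2CCOCC2)c1)c1cccc(N)c1O` gives 5060 nM
compound 2 `O=C(N/N=C/c1ccco1)c1cccc(S(=O)(=O)N2CCOCC2)c1` gives only the limit > 100000 nM
compound 3 `O=C(N/N=C/c1ccccn1)c1cccc(S(=O)(=O)N2CCOCC2)c1` gives 55700 nM

Compound 3 holds the highest of the two numbers, with compound 1 lower by a gap beyond the usual scatter. Compound 2 sits at a limit, not a number. Among the compounds with values here, the single measured step at the carbon with a double bond to nitrogen is an at least 1.7-fold lower number from compound 2 to compound 3 (0.25 log units; that floor lies within the scatter), its floor set by the limit of > 100000 nM in this assay, at which 1 of the 3 values shown sits. Compound 4 `COc1ccc(/C=N/NC(=O)c2cccc(S(=O)(=O)N3CCOCC3)c2)c(O)c1` differs from compound 3 by 2-hydroxy-4-methoxyphenyl in place of pyridin-2-yl on a carbon with a double bond to nitrogen. Both that step and the gap between compound 1 and compound 3 show the aryl group on this carbon moving the number, so a lower number is expected for compound 4, roughly a 3.7-fold lower number from compound 3 to compound 4 (0.57 log units; beyond the scatter). Compound 4 is estimated at 15000 nM, in the range 4000 nM to 60000 nM.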

Compound 4, half-maximal inhibitory concentration: 2790 nM
Compound 4: the middle estimate sits 5.4-fold (0.73 log units) above what was measured; the whole stated range lies above it.
By their numbers in this assay, from the lowest: compounds 4 and 1 (each within the scatter of the next); then compound 3. At a limit, above all of these: compound 2.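

On the carbon with a double bond to nitrogen, the aryl group can move the number well beyond the scatter: a 20-fold lower number from compound 3 to compound 4 (1.30 log units; beyond the scatter). Within the data shown here, the earlier step between furan-2-yl and pyridin-2-yl had only a floor within the scatter, so this is the first clear effect of a single change here. Compound 2 stands at a limit, so an at least 35-fold lower number from compound 2 to compound 4 (1.55 log units; beyond the scatter) is a floor only: the limit of > 100000 nM in this assay, at which 1 of the 4 values shown sits.

The change replaces the ring and adds hydroxy and methoxy together, and the compounds shown do not separate these parts. Going by these compounds, how an unsubstituted phenyl, 2-hydroxyphenyl or 4-methoxyphenyl group on this carbon compares remains open.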